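Methoxy-to-Hydroxy Exchange in Chromene Chalcones

The source may hold more compounds than are shown below. What is called first, only, known or untested is meant among the compounds shown, and "the series" means these compounds.

Measured compounds:
- Compound 1 `COc1cccc(/C=C/C(=O)c2ccc(OC)c3c2OC(C)(C)C=C3)c1`: 9360 nM
- Compound 2 `COc1ccc(C(=O)/C=C/c2cc(OC)c(OC)c(OC)c2)c2c1C=CC(C)(C)O2`: 9700 nM
- Compound 3 `COc1ccc(C(=O)/C=C/c2cccc(O)c2)c2c1C=CC(C)(C)O2`: > 10000 nM

In a functional assay on SK-OV-3 cells (Homo sapiens) for antiproliferative activity, read by MTT assay, with a stated time of 24 h (on this read-out higher numbers stand for weaker inhibition and lower numbers for stronger inhibition), compound 1 gives 9360 nM. Compound 2 gives 9700 nM in this assay; against compound 1 this is a gap within the usual scatter, so no order between the two is claimed. The difference between the cores of compound 1 and compound 2 is not broken down here. For compound 3 the value in this assay is a limit, > 10000 nM, not a number (the limit of > 10000 nM in this assay, at which 1 of the 3 values shown sits).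

The change from compound 1 to compound 3 is hydrogen in place of methyl on an oxygen on an aromatic ring and gave an at least 1.0-fold higher number from compound 1 to compound 3 (0.02 log units; that floor lies within the scatter). The unmeasured compound 4 `COc1cc(/C=C/C(=O)c2ccc(OC)c3c2OC(C)(C)C=C3)cc(OC)c1O` carries the same change against compound 2, namely (hydrogen in place of methyl on an oxygen on an aromatic ring), at a place described in identical words.

Resting on compound 1 and compound 3, with the step of an at least 1.0-fold higher number from compound 1 to compound 3 (0.02 log units; that floor lies within the scatter), the expected step is a 1.2-fold higher number from compound 2 to compound 4 (0.09 log units; within the scatter). Compound 4 is therefore expected to give about 12000 nM in this assay, with a range from 6000 nM to 30000 nM, and a fair chance that only a limit is reported.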

Compound 4, half-maximal inhibitory concentration: > 10000 nM
Compound 4: only a limit was reported; the forecaster's own chance of this, stated with the estimate: 55%; the middle value does not contradict the limit.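

In this assay compound 4 gives > 10000 nM, which is a limit of the assay and not a number. The exchange of methoxy to hydroxy on this core therefore reads only as an at least 1.0-fold higher number from compound 2 to compound 4 (0.01 log units; that floor lies within the scatter). On both cores the hydroxy compound ends at a limit and neither reads as stronger than its methoxy partner, but this shows neither how large the two steps really are nor that one size of step carries from one core to the other: the same change on two cores in this assay, an at least 1.0-fold higher number (0.02 log units; that floor lies within the scatter) from compound 1 to compound 3 and an at least 1.0-fold higher number (0.01 log units; that floor lies within the scatter) from compound 2 to compound 4; the limit leaves it open whether they differ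

The compounds shown leave open what other groups would do at the same place on the aromatic ring, for example an amine, an ethoxy group or a carboxylic acid. On these data alone, it also remains open whether the methoxy to hydroxy exchange would give a step of readable size on a core whose methoxy compound starts at a much lower number in this assay.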